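One added methoxy on compound 2

The compounds below may be only part of what the source reports. "The series", "measured", "known", "first", "only" and "open" are said of these compounds alone.

- Compound 1 `COc1cc(OC)c(OC)cc1/C=C/C(=O)/C=C/c1cc2ccccc2nc1Cl` gives 3120 nM
- Compound 2 `COc1ccc(OC)c(/C=C/C(=O)/C=C/c2cc3ccccc3nc2Oc2cccc(Cl)c2)c1` gives > 10000 nM

In a functional assay on PC-3 cells (Homo sapiens) for cytotoxicity, read by MTT assay, with a stated time of 48 h (on this read-out lower numbers stand for stronger inhibition and higher numbers for weaker inhibition), compound 2 stands at > 10000 nM as a limit and not a number. Compound 3 `COc1cc(OC)c(OC)cc1/C=C/C(=O)/C=C/c1cc2ccccc2nc1Oc1cccc(Cl)c1` takes methoxy in place of hydrogen on an aromatic carbon, so 2,5-dimethoxyphenyl becomes 2,4,5-trimethoxyphenyl. In this assay compound 1, which also carries that group, gives 3120 nM as a true number. On that ground the step of an at least 1.4-fold lower number from compound 2 to compound 3 (0.15 log units; that floor lies within the scatter) is expected to be modest and toward stronger inhibition, though compound 3 may also stay at the limit. For compound 3 the expected value is 7000 nM (estimated range 2000 nM to 20000 nM).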

Compound 3, half-maximal inhibitory concentration: > 10000 nM
Compound 3 gave a limit, no number (the forecaster's own chance of this, stated with the estimate: 40%); middle value at least 1.4-fold (0.15 log units) from the limit.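

In this assay, with 2,4,5-trimethoxyphenyl held in place, 3-chlorophenoxy in place of chloro gives an at least 3.2-fold higher number from compound 1 to compound 3 (0.50 log units; beyond the scatter). The added methoxy does not bring the 3-chlorophenoxy compounds to a true number: compound 3 gives > 10000 nM, which is a limit. The step between compound 2 and compound 3 cannot be read because both values are limits: the limit of > 10000 nM in this assay, at which 2 of the 3 values shown sit.

As far as these compounds go, what the added methoxy does with chloro in place of 3-chlorophenoxy stays open. So does whether an amine at that place would give a true number in this assay.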